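Bromo in place of hydrogen: compound 2 to compound 3

The source may report more compounds than this note shows. Statements on the series, on what has been measured and on what is new or still open speak of the compounds shown alone.

Two compounds of the series have numbers in a functional assay on A549 cells (Homo sapiens) for antiproliferative activity, read by MTT assay, with a stated time of 48 h; a higher number here means a weaker inhibitor, a lower number a stronger inhibitor. Compound 1 `Cc1ncc([N+](=O)[O-])n1CC(=O)NS(=O)(=O)c1ccc(F)cc1` gives 1.26 ug/mL. Among the compounds with values here, compound 2 `Cc1ncc([N+](=O)[O-])n1CC(=O)NS(=O)(=O)c1ccccc1` gives 3.96 ug/mL, the highest of the two numbers; its nearest neighbour is compound 1, and the single measured step, a 3.1-fold higher number from compound 1 to compound 2 (0.50 log units; beyond the scatter), lies beyond the scatter.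

Compound 3 `Cc1ncc([N+](=O)[O-])n1CC(=O)NS(=O)(=O)c1ccc(Br)cc1` differs from compound 2 by bromo in place of hydrogen on an aromatic carbon, on an aromatic carbon of a six-membered aromatic ring of carbon only, para to a large group. Within the data shown here, the only measured step that bears on this change is a 3.1-fold higher number from compound 1 to compound 2 (0.50 log units; beyond the scatter), which took a halogen away from that same place and raised the number by a modest amount. Returning a halogen to that place is therefore expected to lower the number in this assay by a step of similar size, though nothing measured shows whether bromo behaves like fluoro here, so the range is kept wide. For compound 3 the estimate in this assay is 1.5 ug/mL, with a range from 0.6 ug/mL to 4 ug/mL. The expected step is a 2.6-fold lower number from compound 2 to compound 3 (0.42 log units; beyond the scatter).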

Compound 3, half-maximal inhibitory concentration: 3.03 ug/mL
Estimate against measurement, compound 3: 2.0-fold (0.31 log units) below; the range from low to high includes it.
By their numbers in this assay, from the lowest: compound 1; then compounds 3 and 2 (each within the scatter of the next).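

In this assay, putting bromo at this place, on the aromatic carbon para to a large group, gives a 1.3-fold lower number from compound 2 to compound 3 (0.12 log units; within the scatter), so phenyl and 4-bromophenyl cannot be told apart here and a halogen at this place does not by itself go with a lower number. Exchanging one halogen for the other at the same carbon gives a 2.4-fold higher number from compound 1 to compound 3 (0.38 log units; beyond the scatter), which shows that the outcome at this position depends on which halogen stands there, a point the earlier pair of compounds could not settle. Among the three compounds, compound 1 with fluoro is the only one that stands apart from the others beyond the scatter, and no information at hand accounts for the difference between fluoro and bromo.

As far as these compounds go, it remains open whether chloro or iodo at this place would fall with compound 1 or with compound 3, which would show whether fluoro is a special case among the halogens. From the compounds shown here alone, it is also open whether a group other than a halogen at this carbon, such as methoxy, an amine or a carboxylic acid, could reach the level of compound 1.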